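Swapping a Methyl for Bromo on the Anilino Ring

This account rests on a few compounds, and the source may have more. Where it says the series, first, only, none or still open, it means among the compounds named here.

Of the compounds shown here, three share a common core and have been tested in an assay for displacement of a labelled ligand from corticotropin-releasing factor receptor 1 (Homo sapiens); a higher number here means a weaker inhibitor, a lower number a stronger inhibitor. Compound 1 `CCCN(CC1CC1)C(=O)c1sc(Nc2c(C)cc(C)cc2C)nc1C` gives 2600 nM in this assay. Compound 2 `CCCN(CC1CC1)C(=O)c1sc(Nc2c(Cl)cc(Cl)cc2Cl)nc1CC` gives 11000 nM in this assay. Compound 3 `CCCN(Cc1sc(Nc2c(C)cc(C)cc2Br)nc1C(F)(F)F)CC1CC1` gives 21 nM in this assay, the lowest of the three numbers; its nearest neighbour is compound 1, whose number is higher by a margin beyond the usual scatter, and compound 2 lies further away still, also beyond the scatter. Compounds 1 and 2 differ from compound 3 in several places at once. Those gaps cannot be tied to any single change.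

The step under consideration leads to compound 4 `CCCN(Cc1sc(Nc2c(Br)cc(C)cc2Br)nc1C(F)(F)F)CC1CC1`, which differs from compound 3 by bromo in place of methyl on an aromatic carbon. Among the compounds with values here, no pair of measured compounds isolates this exact exchange, so there is no measured step to lean on. The change is small in what it counts, one heavy atom for one heavy atom, with no change in donors, acceptors or charge. The expectation is therefore a step of modest size, a 1.2-fold higher number from compound 3 to compound 4 (0.08 log units; within the scatter), not clearly beyond the scatter in either direction. On that basis compound 4 is expected to give about 25 nM in this assay, within a range from 8 nM to 80 nM.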

Compound 4, inhibition constant: 28 nM
Beside the measured number, compound 4's estimate is 1.1-fold (0.05 log units) below it, and the stated range covers the measured number.
By their numbers in this assay, from the lowest: compounds 3 and 4 (each within the scatter of the next); then compound 1; then compound 2.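

Within the data shown here, compounds 3 and 4 form the first pair here that differs in one place only, so this exchange can finally be read on its own: in this assay, bromo in place of methyl on an aromatic carbon, ortho to a large group, gives a 1.3-fold higher number from compound 3 to compound 4 (0.12 log units; within the scatter). Among these compounds, a 2-bromo-4,6-dimethylphenyl group and a 2,6-dibromo-4-methylphenyl group therefore cannot be told apart by this measurement, and the earlier compounds, which differ in several places at once, could not show that. No other measurement is available to explain why the two groups read alike, so the result stands as an observation only.

The compounds shown leave open how other groups at this same place would read, for example a methoxy group, a nitrile or an amine, since methyl and bromo are the only two seen in a single-place comparison here. They also leave open which of the several differences separating compound 1 and compound 2 from compound 3 accounts for the large gaps in their numbers, and those gaps cannot be read as steps.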